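The compounds below may be only part of what the source reports. "The series", "measured", "known", "first", "only" and "open" are said of these compounds alone.

Compound 1 `CCOc1ccc(C(=O)/C=C/c2ccc(C(=O)Nc3cccc(-c4cc(C(=O)OC)no4)c3)cc2)cc1` in an ADME assay on Vero cells (Chlorocebus sabaeus) for cytotoxicity, read by MTT assay, with a stated time of 72 h (on this read-out lower numbers stand for higher toxicity in this test and higher numbers for lower toxicity in this test), gives > 40 ug/mL, which is a limit of the assay.
Compound 2 `COC(=O)c1cc(-c2cccc(NC(=O)c3ccc(/C=C/C(=O)c4ccc(Cl)cc4)cc3)c2)on1` in this assay gives > 50 ug/mL, again a limit of the assay.

Compound 2 thus stands at one of the two limits, (the limit of > 50 ug/mL in this assay, at which 1 of the 2 values shown sits), while compound 1 sits at the other, (the limit of > 40 ug/mL in this assay, at which 1 of the 2 values shown sits). Within the data shown here, the single measured step, a step that the two limits leave unreadable from compound 1 to compound 2, alters the ring on the carbonyl carbon, but its size cannot be read from two limits. Compound 3 `COC(=O)c1cc(-c2cccc(NC(=O)c3ccc(/C=C/C(=O)c4ccc(OC)cc4OC)cc3)c2)on1` differs from compound 2 in that (2,4-dimethoxyphenyl in place of 4-chlorophenyl on a carbonyl carbon). Among the measured compounds shown here, no measured step gives a readable size for such a change in this assay, and the two limits offer no direction. The step from compound 2 to compound 3 is therefore expected to be none beyond the scatter, a step that the limit leaves unreadable from compound 2 to compound 3. Compound 3 is estimated to give about 60 ug/mL in this assay, with a range from 30 ug/mL to 120 ug/mL, and most likely to be reported only as a limit.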

Compound 3, half-maximal cytotoxic concentration: > 50 ug/mL
Compound 3 ended at the assay's limit (the forecaster's own chance of this, stated with the estimate: 75%); the middle value is on the limit's open side.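

Among these compounds, all three values in this assay are limits of the assay, so no step among compound 1, compound 2 and compound 3 can be read. The compounds shown leave open where each half-maximal cytotoxic concentration lies, and whether exchanging the aryl group on the carbonyl carbon changes it.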